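The source may report more compounds than this note shows. Statements on the series, on what has been measured and on what is new or still open speak of the compounds shown alone.

In a functional assay on SMMC-7721 cells (Homo sapiens) for cytotoxicity, read by MTT assay, with a stated time of 72 h (on this read-out lower numbers stand for stronger inhibition and higher numbers for weaker inhibition), compound 1 `O=C1C(=Cc2ccc(Br)cc2)C(=O)N(c2ccc(Cl)cc2)N1c1ccc(Cl)cc1` gives 16600 nM and compound 2 `O=C1C(=Cc2cccc(Cl)c2)C(=O)N(c2ccc(Cl)cc2)N1c1ccc(Cl)cc1` gives 20200 nM, with a 1.2-fold higher number from compound 1 to compound 2 (0.09 log units; within the scatter). Compound 3 `COc1ccc(C=C2C(=O)N(c3ccc(Cl)cc3)N(c3ccc(Cl)cc3)C2=O)cc1OC` gives only a limit, > 128000 nM, and stands at the weak end of the three. Compound 4 `O=C1C(=C/C=C/c2ccccc2)C(=O)N(c2ccc(Cl)cc2)N1c1ccc(Cl)cc1` carries 2-phenylethenyl in place of 3,4-dimethoxyphenyl on a double-bonded chain carbon bound to a double-bonded ring carbon. Within the data shown here, two measured steps bear on this, since each brings 3,4-dimethoxyphenyl in at the same place: an at least 7.7-fold higher number from compound 1 to compound 3 (0.88 log units; beyond the scatter) and an at least 6.3-fold higher number from compound 2 to compound 3 (0.80 log units; beyond the scatter). Removing that group is therefore expected to move the number down by a similar size. The expected step is an at least 3.6-fold lower number from compound 3 to compound 4 (0.56 log units; beyond the scatter). For compound 4 the estimate is 35000 nM, within a range of 12000 nM to 110000 nM.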

Compound 4, half-maximal inhibitory concentration: 10100 nM
Beside the measured number, compound 4's estimate is 3.5-fold (0.54 log units) above it; measured number below the stated range.
By their numbers in this assay, from the lowest: compounds 4, 1 and 2 (each within the scatter of the next). At a limit, above all of these: compound 3.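

In this assay, 2-phenylethenyl on a double-bonded chain carbon bound to a double-bonded ring carbon stays level with both halogen-bearing phenyl groups, with a 2.0-fold lower number from compound 2 to compound 4 (0.30 log units; within the scatter) and a 1.6-fold lower number from compound 1 to compound 4 (0.22 log units; within the scatter). Against 3,4-dimethoxyphenyl the same change gives an at least 12-fold lower number from compound 3 to compound 4 (1.10 log units; beyond the scatter), so the weak result is not shared by this larger replacement. Compound 3 stands at a limit, which makes that step a bound only: the limit of > 128000 nM in this assay, at which 1 of the 4 values shown sits.

Going by these compounds, it remains open whether a single methoxy group or an amine on the phenyl ring would keep the level of compound 1, compound 2 and compound 4. On these data alone, whether a longer chain carrying the phenyl ring would do the same also remains open.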